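A Chlorine Added to the Fused Ring of Compound 1

A few compounds are considered here, and "the series" means these few. Any claim that something is new, unique, unknown or untested is made for them only; others in the source may bear on it.

Compound 1 `CS(=O)(=O)c1ccc(Nc2ncc(F)c(Nc3nc4ccccc4s3)n2)cc1` gives 2830 nM in a functional assay on PC-3 cells (Homo sapiens) for antiproliferative activity, read by MTT assay, with a stated time of 48 h; on this read-out lower numbers stand for stronger inhibition and higher numbers for weaker inhibition.
Compound 2 `CS(=O)(=O)c1ccc(Nc2nccc(Nc3nc4ccccc4s3)n2)cc1` gives 1710 nM in this assay.
Compound 3 `Cc1cnc(Nc2ccc(S(C)(=O)=O)cc2)nc1Nc1nc2ccccc2s1` gives > 50000 nM in this assay, which is a limit of the assay and not a number.

Among the numbers shown, compound 1 stands highest, but its only neighbour with a plain number, compound 2, lies within the scatter of it, so the two cannot be told apart. Compound 3 sits at the limit (the limit of > 50000 nM in this assay, at which 1 of the 3 values shown sits), so only a bound is known for it.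

Compound 4 `CS(=O)(=O)c1ccc(Nc2ncc(F)c(Nc3nc4ccc(Cl)cc4s3)n2)cc1` differs from compound 1 in one place: chloro in place of hydrogen on an aromatic carbon.

The measured steps all change a substituent on the other ring of the shared core, not the fused ring where the chloro enters. a 1.7-fold lower number from compound 1 to compound 2 (0.22 log units; within the scatter), which lies within the scatter. an at least 17-fold higher number from compound 1 to compound 3 (1.24 log units; beyond the scatter) and an at least 29-fold higher number from compound 2 to compound 3 (1.46 log units; beyond the scatter), both large. None of them places any group on the fused ring, so none bears directly on the change to compound 4. For compound 4 a step within the scatter is therefore expected, a 1.3-fold lower number from compound 1 to compound 4 (0.11 log units; within the scatter). Compound 4 is estimated at 2200 nM, with a range from 600 nM to 8000 nM.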

Compound 4, half-maximal inhibitory concentration: > 50000 nM
Compound 4 was reported as a limit; the forecaster's own chance of this, stated with the estimate: 8%; middle value at least 22-fold (1.35 log units) away from the limit.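

Placing chloro on the fused ring, a part of the shared core that no earlier step touched, gives an at least 17-fold higher number from compound 1 to compound 4 (1.24 log units; beyond the scatter) in this assay. On these data alone, compound 4 is reported only as a limit, not as a number, so the true size of this step is unknown and it could be larger than printed: the limit of > 50000 nM in this assay, at which 2 of the 4 values shown sit. The earlier compounds shown here showed a large step only for a change on the other ring, such as an at least 17-fold higher number from compound 1 to compound 3 (1.24 log units; beyond the scatter), whereas this result shows that the fused ring can also produce a large step, here through the entry of a single chlorine atom in place of a hydrogen atom.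

The compounds shown cannot tell whether this loss belongs to chloro alone or would follow any group placed here, since no other group, such as a smaller fluoro, a methoxy, an amine or a carboxylic acid, appears at this position. They also leave open whether chloro would give a similar step on compound 2, which carries hydrogen in place of the fluoro of compound 1.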